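This account rests on a few compounds, and the source may have more. Where it says the series, first, only, none or still open, it means among the compounds named here.

Measured in a physicochemical assay for lipophilicity, read by HPLC, at pH 7.5; a lower number here means a more polar compound, a higher number a more lipophilic compound:
- Compound 1 `CCOc1ccccc1-c1ccc(-c2nc3cnccc3cc2C#N)cc1`: 3.8
- Compound 2 `CCOc1ccccc1-c1ccc(-c2nc3cnccc3c(NC(C)C(=O)O)c2C#N)cc1`: 2.1
- Compound 3 `CC[C@@H](Nc1c(C#N)c(-c2ccc(-c3ncccc3C)cc2)nc2cnccc12)C(N)=O`: 2

Compound 2 sits level with compound 3, as their two values lie within the usual scatter of each other, and clearly beneath compound 1. The next compound to consider is compound 4 `CCOc1ccccc1-c1ccc(-c2nc3cnccc3c(N[C@H](CC)C(=O)N(C)C)c2C#N)cc1`, which has not yet been measured. It keeps the rest of compound 2 and changes one group: 1-(dimethylcarbamoyl)propyl in place of 1-carboxyethyl on a nitrogen on an aromatic ring. In words, 1-(dimethylcarbamoyl)propyl takes the place of 1-carboxyethyl on a nitrogen on an aromatic ring.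

Among the compounds with values here, one measured step bears directly on this change. The (1-carboxyethyl)amino group now leaving arrived in a number 1.70 log units lower from compound 1 to compound 2 (beyond the scatter), a large step beyond the scatter, so a rise is expected in this assay once it goes. The nitrogen stays, however, and carries a new chain, so a simple return to the number of compound 1 is not assumed. Within the data shown here, compound 3 also carries an amide-bearing chain on that nitrogen and gives 2, but it differs from compound 4 elsewhere too, and no measured step separates those changes. The rise is therefore estimated as a number 1.20 log units higher from compound 2 to compound 4 (beyond the scatter), recovering much but not all of the earlier drop. Compound 4 is expected at 3.3, with an estimated range of 2.6 to 4.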

Compound 4, distribution coefficient: 3.7
For compound 4 the middle estimate is 0.40 log units below the measured one; the measured number falls inside the stated range.
By their numbers in this assay, from the lowest: compounds 3 and 2 (each within the scatter of the next); then compounds 4 and 1 (each within the scatter of the next).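

In this assay, the number at this position depends on which chain the nitrogen carries, with a number 1.60 log units higher from compound 2 to compound 4 (beyond the scatter). Within the data shown here, until now the only step here was the fall that came with (1-carboxyethyl)amino, and that step alone could not show whether any chain on this nitrogen would bring such a fall, but a number 0.10 log units lower from compound 1 to compound 4 (within the scatter) shows that (1-(dimethylcarbamoyl)propyl)amino in place of hydrogen on an aromatic carbon leaves the number level with that of the compound carrying hydrogen there. Among these compounds, then, the low number goes with 1-carboxyethyl and not with having a chain on the nitrogen as such, even though the chain that enters is the larger of the two.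

This change alters the end of the chain and its length together, so only a group such as 1-carboxypropyl or 1-(dimethylcarbamoyl)ethyl on the same nitrogen could show which of the two carries the step, and an amine at the chain end remains an open case as well. No independent evidence is available to explain the size of this step.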